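A few compounds are considered here, and "the series" means these few. Any claim that something is new, unique, unknown or untested is made for them only; others in the source may bear on it.

Of the compounds shown here, three sharing one core have been measured in a functional assay on A549 cells (Homo sapiens) for cytotoxicity, read by MTT assay, with a stated time of 48 h; a higher number here means a weaker inhibitor, a lower number a stronger inhibitor. Compound 1 `Cc1ccc(S(=O)(=O)/N=C(/CCNC2=CC(=O)c3ccccc3C2=O)Nc2ccccc2[N+](=O)[O-])cc1` gives 5010 nM, the lowest number of the three. Compound 2 `COc1ccc(N/C(CCNC2=CC(=O)c3ccccc3C2=O)=N\S(=O)(=O)c2ccc(C)cc2)cc1OC` gives 20500 nM, and compound 3 `Cc1ccc(S(=O)(=O)/N=C(/CCNC2=CC(=O)c3ccccc3C2=O)NC(C)C)cc1` gives 44300 nM. Both neighbours sit well apart from compound 1: the step of a 4.1-fold higher number from compound 1 to compound 2 (0.61 log units; beyond the scatter) and the step of an 8.8-fold higher number from compound 1 to compound 3 (0.95 log units; beyond the scatter) are each beyond the scatter, and the step of a 2.2-fold higher number from compound 2 to compound 3 (0.33 log units; beyond the scatter) is smaller but still beyond it.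

Compound 4 `Cc1ccc(S(=O)(=O)/N=C(/CCNC2=CC(=O)c3ccccc3C2=O)NCc2ccccc2)cc1` differs from compound 1 in one place: benzyl in place of 2-nitrophenyl on an amine nitrogen. The two measured steps that bear on this change both swap the same 2-nitrophenyl for something else, and both weakened inhibition, modestly with 3,4-dimethoxyphenyl and more with isopropyl. Benzyl keeps an aromatic ring yet loses the two hydrogen-bond acceptors, so a weakening of a size between those two steps seems the likeliest outcome. Compound 4 is therefore expected to show a step of a 5.0-fold higher number from compound 1 to compound 4 (0.70 log units; beyond the scatter) in this assay. The estimated value of compound 4 in this assay is 25000 nM, with a range from 8000 nM to 60000 nM.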

Compound 4, half-maximal inhibitory concentration: 7410 nM
Compound 4: the middle estimate sits 3.4-fold (0.53 log units) above what was measured; the whole stated range lies above it.
By their numbers in this assay, from the lowest: compounds 1 and 4 (each within the scatter of the next); then compound 2; then compound 3.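

In this assay, benzyl in place of 2-nitrophenyl gives a 1.5-fold higher number from compound 1 to compound 4 (0.17 log units; within the scatter) and so leaves the number within the scatter, which shows that in this pair a group with 0 hydrogen-bond acceptors serves as well on this amine nitrogen as one with 2. Benzyl also stands clear of isopropyl, with a 6.0-fold lower number from compound 3 to compound 4 (0.78 log units; beyond the scatter) in this series, and of 3,4-dimethoxyphenyl, with a 2.8-fold lower number from compound 2 to compound 4 (0.44 log units; beyond the scatter) here, so compound 2 goes against any simple rule that an aromatic ring on this nitrogen is enough for a low number. Nothing measured here accounts for these differences.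

Open, on these data alone, is whether a longer chain, such as 2-phenylethyl, would keep the number of compound 4. Also open, as far as these compounds go, is whether a saturated cyclohexylmethyl group would do so without an aromatic ring.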